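Aryl sulfone trimming: compound 3 to compound 4

A few compounds are considered here, and "the series" means these few. Any claim that something is new, unique, unknown or untested is made for them only; others in the source may bear on it.

Measured compounds in an assay on isolated protein for displacement of a labelled ligand from metabotropic glutamate receptor 5 (Homo sapiens), with a stated time of 60 min, tested at 1 uM; a higher number here means more inhibition at the concentration tested (going by the name of the read-out), a lower number less inhibition:
- compound 1 `CC1CCN(c2c(S(=O)(=O)c3ccc(C#N)cc3)cnc3cc(F)ccc23)CC1`: 83%
- compound 2 `Cc1ccc(S(=O)(=O)c2cnc3cc(Cl)ccc3c2N2CCC(C)CC2)cc1`: 94%
- compound 3 `Cc1ccc(S(=O)(=O)c2cnc3cc(F)ccc3c2N2CCC(C)CC2)cc1C`: 90%

Compound 3 stands second of the three numbers; compound 2 is the nearest, and compound 1 the furthest, and both gaps are within the scatter, so the three compounds cannot be ordered on these data.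

Among the compounds with values here, the only single-point step on the sulfonyl aryl group is a number 7 percentage points higher from compound 1 to compound 3 (within the scatter), a change that stayed within the scatter even though it swapped a nitrile-bearing ring for a dimethyl-bearing one. Compound 4 `Cc1ccc(S(=O)(=O)c2cnc3cc(F)ccc3c2N2CCC(C)CC2)cc1` is reached from compound 3 by hydrogen in place of methyl on an aromatic carbon. Compound 2 already carries the 4-methylphenyl on its sulfonyl sulfur, differing from compound 4 only in the halogen on the shared core, and its value in this assay sits close to that of compound 3. Given the flat step from compound 1 to compound 3, the removal of one methyl is expected to move the number in this assay by no more than the scatter, with the estimated step of no change at the digits printed from compound 3 to compound 4 (within the scatter). Compound 4 is therefore estimated at 90%, within 80% to 97%.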

Compound 4, a percentage reported as inhibition, at one concentration (the size of the read-out at that concentration, not a potency): 88%
Estimate against measurement, compound 4: 2 percentage points above; the range from low to high includes it.
By their numbers in this assay, from the lowest: compounds 1, 4, 3 and 2 (each within the scatter of the next, the first and the last beyond it).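

In this assay the change from 3,4-dimethylphenyl to 4-methylphenyl gives a number 2 percentage points lower from compound 3 to compound 4 (within the scatter) and so shows that this methyl, ortho to a methyl group, can be replaced by hydrogen without a step beyond the scatter. Compound 4 also allows two further single-place readings, with a number 5 percentage points higher from compound 1 to compound 4 (within the scatter) for methyl in place of cyano on an aromatic carbon and a number 6 percentage points lower from compound 2 to compound 4 (within the scatter) for fluoro in place of chloro on an aromatic carbon, and both steps are flat within the scatter. No measurement at hand offers an explanation for these flat steps.

Still open, on these data alone, is how this aromatic carbon responds to a methoxy group, an amine or a carboxylic acid in place of hydrogen. Readings at a single concentration also leave the potency of these compounds undefined.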